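Side-chain amide to benzyl ester: working notes

This account rests on a few compounds, and the source may have more. Where it says the series, first, only, none or still open, it means among the compounds named here.

Measured so far in this series:
compound 1 `NC(=O)CC[C@H](NC(=O)CN(c1ncnc2c1ncn2C1CCCCO1)C1CC1)C(=O)OCc1ccccc1`: 10.7%
compound 2 `O=C(CN(c1ncnc2c1ncn2C1CCCCO1)C1CC1)N[C@@H](CCC(=O)OCc1ccccc1)C(=O)OCc1ccccc1`: 14.1%
compound 3 `NC(=O)C[C@H](NC(=O)CN(c1ncnc2c1ncn2C1CCCCO1)C1CC1)C(=O)OCc1ccccc1`: 21.7%

In a functional assay on the whole organism (Tail, strain ICR) with Mus musculus as the target, in the tail flick test, with a stated time of 150 min, at a dose of 25 umol/kg by the oral route (a higher number here means a stronger effect of the compound at the dose given, a lower number a weaker effect), compound 1 gives 10.7%. In the same test compound 2 gives 14.1%, and compound 3 gives 21.7%.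

Compound 1 and compound 2 share a core and differ only at the side chain, where (benzyloxy in place of amino on a carbonyl carbon). The step this made was a number 3.4 percentage points higher from compound 1 to compound 2 (within the scatter). The core of compound 3 differs from the core of compound 1 in that (carbamoyl in place of carbamoylmethyl on a saturated chain carbon, two bonds along the chain from an amide-type nitrogen and a carbonyl carbon); this gave a number 11 percentage points higher from compound 1 to compound 3 (beyond the scatter). Between compound 2 and compound 3 the change is larger in structure, and the step was a number 7.6 percentage points higher from compound 2 to compound 3 (within the scatter).

Compound 4 `O=C(CN(c1ncnc2c1ncn2C1CCCCO1)C1CC1)N[C@@H](CC(=O)OCc1ccccc1)C(=O)OCc1ccccc1` has not yet been measured in this assay. It is built on the core of compound 3 and differs from compound 3 in that (benzyloxy in place of amino on a carbonyl carbon). The place of this change reads the same as for the pair compound 1 to compound 2, so it is the same change, now made on the shorter side chain. Among the compounds with values here, only one earlier instance exists, and it stayed within the scatter. The step from compound 3 to compound 4 in this assay is therefore expected to be small, a number 2.3 percentage points higher from compound 3 to compound 4 (within the scatter), because a number 3.4 percentage points higher from compound 1 to compound 2 (within the scatter) was itself within the scatter. On that basis compound 4 is estimated at 24% in this assay, expected to fall between 12% and 36%.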

Compound 4, a percentage reported as activity, at one dose (the size of the read-out at that dose, not a potency): 0.06%
Compound 4: middle estimate off by 23.9 percentage points, on the high side; measured number below the stated range.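

The change of amino to benzyloxy on the carbonyl carbon does not carry over with the same result from the core of compound 1 to the core of compound 3 in this assay: the same change on two cores in this assay, a number 3.4 percentage points higher (within the scatter) from compound 1 to compound 2 and a number 21.6 percentage points lower (beyond the scatter) from compound 3 to compound 4, 25 percentage points apart, beyond the scatter of two such steps

The other two new steps point the same way, with a number 14 percentage points lower from compound 2 to compound 4 (beyond the scatter) and a number 10.6 percentage points lower from compound 1 to compound 4 (beyond the scatter), and together with a number 21.6 percentage points lower from compound 3 to compound 4 (beyond the scatter) they leave compound 4 as the weakest of the four in this assay. This rests on a single pair on each core, read at one dose and one time, so it shows that the step cannot be assumed to transfer between these two cores, but it does not show what lies behind the difference or how the change would behave on any other core.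

The compounds shown leave open whether the low value of compound 4 belongs to the benzyl ester on the shorter side chain as such, which a carboxylic acid or a methyl ester at that place would help to settle. They also leave open whether a longer chain than those shown, carrying a carbamoyl or a benzyloxycarbonyl end, would follow compound 1 and compound 2 or compound 3 and compound 4.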